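A few compounds are considered here, and "the series" means these few. Any claim that something is new, unique, unknown or untested is made for them only; others in the source may bear on it.

Among the measured compounds shown here, compound 1 `Cc1cnc(OC[C@@]2(c3ccccc3)C[C@H]2C(=O)Nc2ccc(C#N)cn2)c(C)n1` holds the higher of the two numbers measured so far in an assay on isolated protein for binding affinity to Orexin receptor type 2 (Homo sapiens), read by radioligand binding; on this read-out lower numbers stand for stronger inhibition and higher numbers for weaker inhibition: compound 1 gives 21 nM, while compound 2 `CCn1cc(OCC2(c3ccccc3)CC2C(=O)Nc2ccc(C#N)cn2)c(C)n1` gives 10 nM, a gap beyond the usual scatter. Compound 3 `CCn1cc(OC[C@@]2(c3ccccc3)C[C@H]2C(=O)Nc2ccc(C#N)cn2)c(C)n1` is compound 1 with a single change: 1-ethyl-3-methyl-1H-pyrazol-4-yl in place of 3,5-dimethylpyrazin-2-yl on an oxygen on a saturated carbon. Because compound 2, which carries the same 1-ethyl-3-methyl-1H-pyrazol-4-yl group without defined stereochemistry, gives 10 nM, the step from compound 1 is expected to run downward, toward stronger binding, by about a 2.6-fold lower number from compound 1 to compound 3 (0.42 log units; beyond the scatter). For compound 3 the estimated value in this assay is 8 nM, within a likely range from 3 nM to 25 nM.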

Compound 3, inhibition constant in the Orexin receptor type 2 assay: 8 nM
Compound 3: the middle estimate sits on the measured number at the digits printed, and the stated range covers the measured number.
By their numbers in the Orexin receptor type 2 assay, from the lowest: compounds 3 and 2 (each within the scatter of the next); then compound 1.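

With the drawn configuration the same in both compounds, replacing 3,5-dimethylpyrazin-2-yl with 1-ethyl-3-methyl-1H-pyrazol-4-yl on the oxygen can now be read directly in the Orexin receptor type 2 assay, where compound 1 gives 21 nM and compound 3 gives 8 nM: a 2.6-fold lower number from compound 1 to compound 3 (0.42 log units; beyond the scatter). In a physicochemical assay for solubility, in phosphate buffer, at pH 7.4 (on this read-out lower numbers stand for lower solubility and higher numbers for higher solubility), compound 1 gives 47000 nM and compound 3 gives 64000 nM, and the same change gives a 1.4-fold higher number from compound 1 to compound 3 (0.13 log units; within the scatter), so the stronger binding comes with no solubility shift beyond the scatter. In the Orexin receptor type 2 assay there is also a 1.3-fold lower number from compound 2 to compound 3 (0.10 log units; within the scatter), but this says little about configuration, since the comparison rests on: the fact that one of compounds 2 and 3 is drawn with a defined configuration and the other without, at the place where they differ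

From the compounds shown here alone, how the opposite configuration of compound 3 behaves on its own stays open. So does the effect of a propyl chain or an amine in place of the ethyl of the 1-ethyl-3-methyl-1H-pyrazol-4-yl group.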